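Notes on a side-chain swap, compound 2 to compound 3

A few compounds are considered here, and "the series" means these few. Any claim that something is new, unique, unknown or untested is made for them only; others in the source may bear on it.

Measured so far in an ADME assay on liver for metabolic stability, with Liver microsome (Homo sapiens) as the target, read by LC-MS, using microsomes (on this read-out higher numbers stand for fast clearance and lower numbers for slow clearance), for two compounds:
- compound 1 `CC(C)(C)[C@@H](O)C(=O)N1C[C@H]2C[C@H]2[C@H]1C(=O)NCc1cc(Cl)ccc1-n1cnnn1` at 22 mL.min-1.g-1
- compound 2 `CC1(C[C@@H](O)C(=O)N2C[C@H]3C[C@H]3[C@H]2C(=O)NCc2cc(Cl)ccc2-n2cnnn2)CC1` at 12 mL.min-1.g-1

Compound 2 stands within the scatter of compound 1, so these two numbers do not separate. The next change leads to compound 3 `O=C(NCc1cc(Cl)ccc1-n1cnnn1)[C@@H]1[C@@H]2C[C@@H]2CN1C(=O)[C@H](O)c1ccccc1F` and is counted as 2-fluorophenyl in place of (1-methylcyclopropyl)methyl on a saturated chain carbon bound to a carbonyl carbon and an oxygen on a saturated carbon in all: 2-fluorophenyl in place of (1-methylcyclopropyl)methyl on a saturated chain carbon bound to a carbonyl carbon and an oxygen on a saturated carbon.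

For the measured compounds named here, only one measured step bears on this place, a 1.8-fold lower number from compound 1 to compound 2 (0.26 log units; within the scatter), and it exchanged one alkyl group for another. Going by the values given here, no aromatic group has yet been measured here, so that step offers weak guidance and leaves the direction open. In this assay the estimated step is a 1.3-fold higher number from compound 2 to compound 3 (0.10 log units; within the scatter) and is expected to stay inside the scatter, with real uncertainty on either side. For compound 3 the estimated value is 15 mL.min-1.g-1 with an expected range from 6 mL.min-1.g-1 to 38 mL.min-1.g-1 on this read-out.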

Compound 3, intrinsic clearance in microsomes: < 12 mL.min-1.g-1
Compound 3: no number, only a limit; the forecaster's own chance of this, stated with the estimate: 3%; middle value at least 1.2-fold (0.09 log units) from the limit.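

In this assay compound 3 reads < 12 mL.min-1.g-1, which is a limit of the assay and not a number. This is the first read on an aromatic group on a saturated chain carbon bound to a carbonyl carbon and an oxygen on a saturated carbon: the earlier compounds carried only alkyl groups here, and 2-fluorophenyl in place of tert-butyl gives an at least 1.8-fold lower number from compound 1 to compound 3 (0.26 log units; that floor lies within the scatter), so that floor alone does not separate the two compounds, though the true gap may be wider. 2-fluorophenyl in place of (1-methylcyclopropyl)methyl gives a number no higher from compound 2 to compound 3 (the limit leaves the size open) and the limit also caps how finely the series can be ranked at the low end of this read-out: the limit of < 12 mL.min-1.g-1 in this assay, at which 1 of the 3 values shown sits.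

Going by these compounds, how far the true clearance of compound 3 lies under its limit stays open, so its place relative to compound 2 is known only in direction. Also open, on these data alone, is whether the fluorine matters at all, which plain phenyl or a pyridyl ring at the same place would begin to settle.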